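Hydroxymethyl in place of pyridin-2-yl on a shared core

The compounds below may be only part of what the source reports. "The series", "measured", "known", "first", "only" and "open" are said of these compounds alone.

In a functional assay on MiaPaCa cells (Homo sapiens) for antiproliferative activity, read by sulforhodamine B assay, with a stated time of 48 h (on this read-out lower numbers stand for stronger inhibition of growth and higher numbers for weaker inhibition of growth), three compounds with a shared core have been measured. Compound 1 `O=C1COc2ccccc2N1CCCn1cc(-c2ccccc2)nn1` gives the highest number (94000 nM), compound 2 `CCCCCCc1cn(CCCN2C(=O)COc3ccccc32)nn1` gives the lowest (150 nM), and compound 3 `O=C1COc2ccccc2N1CCCn1cc(-c2ccccn2)nn1` lies between them (5800 nM). Compound 3 is therefore second highest of the three, with clear gaps on both sides. Compound 4 `O=C1COc2ccccc2N1CCCn1cc(CO)nn1` has hydroxymethyl in place of pyridin-2-yl on an aromatic carbon of the five-membered aromatic ring with 3 nitrogen (hydroxymethyl in place of pyridin-2-yl on an aromatic carbon). Three measured steps at this same carbon bear on the change, and all are large: pyridin-2-yl in place of phenyl gave a 16-fold lower number from compound 1 to compound 3 (1.21 log units; beyond the scatter) and hexyl in place of phenyl gave a 630-fold lower number from compound 1 to compound 2 (2.80 log units; beyond the scatter) while pyridin-2-yl in place of hexyl gave a 39-fold higher number from compound 2 to compound 3 (1.59 log units; beyond the scatter) as its result. None of these steps involves hydroxymethyl, so they show how far the number can move at this carbon but fix no direction. With no direction supported, no step beyond the scatter is expected, although a large move either way remains possible. The expected step is a 1.7-fold higher number from compound 3 to compound 4 (0.24 log units; within the scatter) as a central estimate. For compound 4 the expected value is 10000 nM with an estimated range from 1500 nM to 60000 nM in this assay.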

Compound 4, concentration for 50% growth inhibition: 1010 nM
Compound 4: middle estimate off by 9.9-fold (1.00 log units), on the high side, and the stated range ends above it.
By their numbers in this assay, from the lowest: compound 2; then compound 4; then compound 3; then compound 1.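

Replacing the ring at this carbon with hydroxymethyl lowers the number in this assay, with a 5.7-fold lower number from compound 3 to compound 4 (0.76 log units; beyond the scatter) and a 93-fold lower number from compound 1 to compound 4 (1.97 log units; beyond the scatter), so among the four groups at this carbon the two without a ring, hexyl and hydroxymethyl, give lower numbers than the two with an aromatic ring, phenyl and pyridin-2-yl, and no compound shown goes against this. A long chain is not needed for much of that gain, yet hexyl keeps a modest lead, with a 6.7-fold higher number from compound 2 to compound 4 (0.83 log units; beyond the scatter), and this shows that the change from a hexyl chain to a short chain bearing a hydroxy does not cancel the advantage over the ring-bearing compounds. Nothing available on the compounds explains these differences.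

The compounds shown leave open whether the hydroxy in compound 4 contributes at all, a question that a plain methyl or an aminomethyl at this carbon would address. They also leave open how the number follows chain length, and whether a chain longer than hexyl, or a hexyl chain ending in a hydroxy or a carboxylic acid, would fall below or above compound 2.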